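Benzyl in place of aryl on the amide nitrogen

The source may report more compounds than this note shows. Statements on the series, on what has been measured and on what is new or still open speak of the compounds shown alone.

Compound 2 `COc1ccc2c(=O)c(/C=C/C(=O)Nc3cc(C)ccc3C)coc2c1` is one of three compounds tested in a functional assay on HeLa cells (Homo sapiens) for inhibition, read by MTT assay, with a stated time of 48 h; on this read-out lower numbers stand for stronger inhibition and higher numbers for weaker inhibition. In this assay, for the measured compounds named here, compound 2 gives 58400 nM, the highest of the two numbers known. Compound 3 `O=C(/C=C/c1coc2cc(O)ccc2c1=O)Nc1ccccc1` gives 9700 nM. For compound 1 `O=C(/C=C/c1coc2cc(O)ccc2c1=O)NCc1ccccc1` the assay reports only a limit, > 100000 nM. Going by the values given here, the one measured step, an at least 10-fold lower number from compound 1 to compound 3 (1.01 log units; beyond the scatter), bears on the change to compound 4 `COc1ccc2c(=O)c(/C=C/C(=O)NCc3ccc(F)cc3F)coc2c1`, which is 2,4-difluorobenzyl in place of 2,5-dimethylphenyl on an amide-type nitrogen. That change runs the other way, a benzyl-type group replacing an aryl group on the amide-type nitrogen, so a step toward a higher number beyond the scatter is expected. Compound 4 is therefore estimated at 150000 nM, with a range from 40000 nM to 500000 nM, an expected step of a 2.6-fold higher number from compound 2 to compound 4 (0.41 log units; beyond the scatter).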

Compound 4, half-maximal inhibitory concentration: > 100000 nM
Compound 4 gave a limit, no number; the forecaster's own chance of this, stated with the estimate: 55%; the middle value does not contradict the limit.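

With an at least 1.7-fold higher number from compound 2 to compound 4 (0.23 log units; that floor lies within the scatter), a benzyl-type group in place of an aryl group on the amide-type nitrogen again fails to lower the number, now with both rings substituted and on a different version of the core. That floor lies within the scatter, so this pair alone fixes neither the size of the step nor its direction. Compound 4 gives a limit and not a number, and the scale ends there for both benzyl compounds: the limit of > 100000 nM in this assay, at which 2 of the 4 values shown sit.

On these data alone, whether an amine or a longer chain in place of 2,4-difluorobenzyl would give a readable number stays open.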